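Shortening the Chloropropyl Urea Chain of Compound 2

A few compounds are considered here, and "the series" means these few. Any claim that something is new, unique, unknown or untested is made for them only; others in the source may bear on it.

Three compounds share a core in which a urea is joined to a benzenesulfonyl group. Compound 1 `CCc1ccccc1OS(=O)(=O)c1cccc(NC(=O)NCCCCl)c1` carries a 2-ethylphenyl on the sulfonyl oxygen, compound 2 `O=C(NCCCCl)Nc1cccc(S(=O)(=O)Oc2ccc(O)cc2)c1` a 4-hydroxyphenyl there, and compound 3 `Cc1ccccc1NS(=O)(=O)c1cccc(NC(=O)NCCCCl)c1` a (2-methylphenyl)amino on the sulfonyl sulfur. In a functional assay on HT-29 cells (Homo sapiens) for cytotoxicity, read by sulforhodamine B assay, with a stated time of 48 h (a lower number here means a stronger inhibitor, a higher number a weaker inhibitor), compound 1 gives 23000 nM, compound 2 gives 51000 nM, and compound 3 gives 42000 nM. Compound 2 stands at the highest number of the three: the step of a 2.2-fold higher number from compound 1 to compound 2 (0.35 log units; beyond the scatter) lies beyond the scatter, whereas the step of a 1.2-fold lower number from compound 2 to compound 3 (0.08 log units; within the scatter) lies within it, so compound 2 and compound 3 cannot be told apart.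

Compound 4 `CCNC(=O)Nc1cccc(S(=O)(=O)Oc2ccc(O)cc2)c1` differs from compound 2 only in the urea chain: hydrogen in place of chloromethyl on a saturated chain carbon, two bonds along the chain from an amide-type nitrogen. Neither measured step touches this chain; both alter the group on the sulfonyl side, so nothing measured bears directly on this change, and the expectation rests on the structure alone. Compound 4 is expected to give 100000 nM in this assay, within a range from 35000 nM to 300000 nM. Going by the values given here, the expected step is a 2.0-fold higher number from compound 2 to compound 4 (0.29 log units; within the scatter), a weakening, but with no measured step to lean on this estimate is loosely held.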

Compound 4, half-maximal inhibitory concentration: 75000 nM
Estimate against measurement, compound 4: 1.3-fold (0.12 log units) above, and the stated range covers the measured number.
By their numbers in this assay, from the lowest: compounds 1, 3, 2 and 4 (each within the scatter of the next, the first and the last beyond it).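

Going by these compounds alone, until now every compound carried the 3-chloropropyl chain on the urea, so compound 4 gives the first reading of this part of the molecule. Replacing chloromethyl with hydrogen, which turns 3-chloropropyl into ethyl, gives in this assay a 1.5-fold higher number from compound 2 to compound 4 (0.17 log units; within the scatter), so with the 4-hydroxyphenyl group in place, this assay cannot tell the ethyl chain from the chlorinated one. No measurement at hand explains this result.

From the compounds shown here alone, compounds 2 and 4 are a single pair, so it remains open whether the same change would also make so little difference with the 2-ethylphenyl group of compound 1 or the (2-methylphenyl)amino group of compound 3. Going by these compounds, it is also open how this assay would read a longer chain such as 4-chlorobutyl, or an amine in place of chloromethyl.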